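From compound 1 to its morpholin-4-yl amide

This account rests on a few compounds, and the source may have more. Where it says the series, first, only, none or still open, it means among the compounds named here.

In a functional assay on OVCAR-3 cells (Homo sapiens) for antiproliferative activity, read by sulforhodamine B assay, with a stated time of 48 h (a higher number here means a weaker inhibitor of growth, a lower number a stronger inhibitor of growth), compound 1 `CCCCCC[C@@H](O)C/C=C\CCCCCCCC(=O)N[C@@H](C)c1ccccc1` gives 11.1 ug/mL. Compound 3 `CCCCCCCC/C=C\CCCCCCCC(=O)N1CCCC1` gives 11.5 ug/mL, which is within the scatter of compound 1. Compound 2 `CCCCCCCCCCCCCCCCCC(=O)N1CCOCC1` gives 43.3 ug/mL, a higher number than compound 1 by more than the scatter.

Compound 4 `CCCCCC[C@@H](O)C/C=C\CCCCCCCC(=O)N1CCOCC1` has morpholin-4-yl in place of (1-phenylethyl)amino on a carbonyl carbon. For the measured compounds named here, no measured pair isolates this change. Compound 2 also carries morpholin-4-yl, though on a different chain, and its 43.3 ug/mL points to a higher number in this assay. A modest step in that direction is expected, near the edge of the scatter: the estimated step is a 2.0-fold higher number from compound 1 to compound 4 (0.30 log units; within the scatter). For compound 4 the estimated value is 22 ug/mL, with an expected range of 10 ug/mL to 45 ug/mL.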

Compound 4, concentration for 50% growth inhibition: 31 ug/mL
Compound 4: the middle estimate sits 1.4-fold (0.15 log units) below what was measured, and the stated range covers the measured number.
By their numbers in this assay, from the lowest: compounds 1 and 3 (each within the scatter of the next); then compounds 4 and 2 (each within the scatter of the next).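

Morpholin-4-yl in place of (1-phenylethyl)amino on a carbonyl carbon is the first single-place change in the series, and in this assay it gives a 2.8-fold higher number from compound 1 to compound 4 (0.45 log units; beyond the scatter). The step is modest, but it shows that this group alone moves the number beyond the scatter, with the rest of compound 1 unchanged. No evidence at hand accounts for the step.

Still open, going by these compounds, is whether the aromatic ring, the amide hydrogen or the defined stereocentre of (1-phenylethyl)amino carries the step, as all three leave together in this change. A piperidin-1-yl or benzylamino group on the same carbonyl carbon would begin to separate them.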